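Pyrazole ureas: N-substituent change on the bis(trifluoromethyl) analogue

The source may report more compounds than this note shows. Statements on the series, on what has been measured and on what is new or still open speak of the compounds shown alone.

Three ureas on the shared core have been measured in an assay on isolated protein for inhibition of STE20-like serine/threonine-protein kinase (Homo sapiens), read by thermal shift assay, tested at 10 uM; a higher number here means that the compound stabilises the target more against heat, a lower number that the compound stabilises the target less. Going by the values given here, compound 1 `CC(C)(C)c1cc(NC(=O)Nc2ccc(F)cc2)n(-c2ccccc2)n1` gives 7.4 degrees C in this assay, and compound 2 `CC(C)(C)c1cc(NC(=O)Nc2ccccc2)n(-c2ccccc2)n1` gives 7.7 degrees C. The one measured step, a number 0.30 degrees C higher from compound 1 to compound 2 (within the scatter), is within the scatter. Compound 3 `Cn1nc(C(C)(C)C)cc1NC(=O)Nc1cc(C(F)(F)F)cc(C(F)(F)F)c1` gives 2.4 degrees C in this assay, the lowest of the three numbers, with compound 1 the nearest and compound 2 the furthest, both beyond the scatter above it. Among the compounds with values here, compound 3 differs from compounds 1 and 2 in two places at once, so no single step connects them; the values only show that compound 3 sits well below both.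

Compound 4 `CC(C)(C)c1cc(NC(=O)Nc2cc(C(F)(F)F)cc(C(F)(F)F)c2)n(-c2ccc(Br)cc2)n1` is compound 3 with 4-bromophenyl in place of methyl on an aromatic nitrogen. Within the data shown here, no measured step bears directly on this change; the fluoro-to-hydrogen step from compound 1 to compound 2 concerns a different position and is within the scatter. Compounds 1 and 2, which carry an aryl group on that aromatic nitrogen, both give higher readings than compound 3, which is the only indication available. On that basis the expected step is a number 3.1 degrees C higher from compound 3 to compound 4 (beyond the scatter) in this assay, upward, but with wide uncertainty. Compound 4 is therefore estimated at 5.5 degrees C, within a range from 2.5 degrees C to 8.5 degrees C.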

Compound 4, shift of the target's melting temperature: 0.1 degrees C
The estimate for compound 4 lay 5.4 degrees C above the measured number, outside the stated range (below it).
By their numbers in this assay, from the lowest: compound 4; then compound 3; then compounds 1 and 2 (each within the scatter of the next).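

Going by these compounds alone, with the urea's bis(trifluoromethyl)phenyl group held constant, compound 3 and compound 4 give the first direct reading of the group on this aromatic nitrogen: in this assay, 4-bromophenyl in place of methyl gives a number 2.3 degrees C lower from compound 3 to compound 4 (beyond the scatter). On this urea, therefore, an aryl group at this position does not bring the reading up towards those of compounds 1 and 2, and the step runs opposite to the direction those compounds had suggested; they differ from compound 4 in more than one place, so their higher readings cannot be attributed to the aryl group on the nitrogen alone. No measurement at hand bears on why the number falls with this change.

Open, as far as these compounds go, is whether the lower reading follows the six-membered aromatic ring itself or the bromine on it, a question that plain phenyl on the same nitrogen, with the bis(trifluoromethyl)phenyl urea kept, would address. Also open, from the compounds shown here alone, is how a longer chain such as ethyl or propyl, or a 4-methoxyphenyl group, would read at this position, and whether the step from methyl to 4-bromophenyl would hold on a urea carrying plain phenyl.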